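The compounds below may be only part of what the source reports. "The series", "measured", "known", "first", "only" and "open" are said of these compounds alone.

Compound 3 `CC[C@@H](Nc1c(C#N)c(-c2ccc(-c3ccccc3N(C)C)cc2)nc2cnccc12)C(N)=O` gives the highest number in a physicochemical assay for lipophilicity, read by HPLC, at pH 7.5 (on this read-out higher numbers stand for higher lipophilicity and lower numbers for lower lipophilicity), at 3.2. Compound 2 `CC[C@@H](Nc1c(C#N)c(-c2ccc(-c3ccccc3COC)cc2)nc2cnccc12)C(N)=O` is nearest, with 2.6; compound 1 `CC[C@@H](Nc1c(C#N)c(-c2ccc(-c3cccc(CO)c3)cc2)nc2cnccc12)C(N)=O` is furthest, with 2. Both steps up to compound 3 lie beyond the scatter: a number 1.20 log units higher from compound 1 to compound 3 (beyond the scatter) and a number 0.60 log units higher from compound 2 to compound 3 (beyond the scatter). Compound 4 `CC[C@@H](Nc1c(C#N)c(-c2ccc(-c3cccc(Cl)c3OC)cc2)nc2cnccc12)C(N)=O` differs from compound 3 in one place: 3-chloro-2-methoxyphenyl in place of 2-(dimethylamino)phenyl on an aromatic carbon. Among the compounds with values here, no measured pair trades these two groups directly. Within the data shown here, the step nearest in kind is a number 0.60 log units higher from compound 2 to compound 3 (beyond the scatter), in which methoxymethyl gave way to dimethylamino; compound 4 again carries a methoxy group, now with chlorine beside it on the ring, a combination no measured pair shows. The expected step is therefore a number 0.10 log units lower from compound 3 to compound 4 (within the scatter), probably within the scatter. Compound 4 is estimated at 3.1, with a range of 2.6 to 3.6.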

Compound 4, distribution coefficient: 3.1
For compound 4 middle estimate and measured number coincide at the digits printed, and the stated range covers the measured number.
By their numbers in this assay, from the lowest: compound 1; then compound 2; then compounds 4 and 3 (each within the scatter of the next).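

In this assay the step is a number 0.10 log units lower from compound 3 to compound 4 (within the scatter) and so, at this position para to a large group, 3-chloro-2-methoxyphenyl and 2-(dimethylamino)phenyl cannot be told apart. With a number 0.50 log units higher from compound 2 to compound 4 (beyond the scatter) and a number 1.10 log units higher from compound 1 to compound 4 (beyond the scatter) as well, a group without dimethylamino also stands clear of compound 1 and compound 2. As far as these compounds go, what a ring with chlorine alone or methoxy alone would give stays open, so the step cannot be shared out between the two, and a carboxylic acid on this ring remains unplaced. No evidence on the cause of these steps is available here.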